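This account rests on a few compounds, and the source may have more. Where it says the series, first, only, none or still open, it means among the compounds named here.

For the measured compounds named here, compound 1, with the structure `CCNC(=O)c1noc(-c2cc(C(C)C)c(O)cc2O)c1-c1cc(CO)no1`, is the stronger of the two compounds measured so far. In a functional assay on HCT-116 cells (Homo sapiens) for inhibition (a higher number here means a weaker inhibitor, a lower number a stronger inhibitor), compound 1 gives 13 nM, the lowest of the two numbers, and the nearest measured neighbour is compound 2. Compound 2, with the structure `CCNC(=O)c1noc(-c2cc(C(C)C)c(O)cc2O)c1-c1cc(COCC(=O)OC)no1`, carries a (methoxycarbonyl)methyl in place of hydrogen on an oxygen on a saturated carbon; in this assay compound 2 gives 262 nM, and the step of a 20-fold higher number from compound 1 to compound 2 (1.30 log units; beyond the scatter) is large and well beyond the scatter.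

Compound 3, with the structure `CCNC(=O)c1noc(-c2cc(C(C)C)c(O)cc2O)c1-c1cc(COCC(N)=O)no1`, has not yet been measured. It differs from compound 1 as follows: carbamoylmethyl in place of hydrogen on an oxygen on a saturated carbon. The only measured step that bears on this change is the one from compound 1 to compound 2, where a different group was attached at the same oxygen and the number rose sharply, as shown by a 20-fold higher number from compound 1 to compound 2 (1.30 log units; beyond the scatter). Going by the values given here, a weakening of similar direction is therefore expected for compound 3, perhaps somewhat smaller, because a 20-fold higher number from compound 1 to compound 2 (1.30 log units; beyond the scatter) is the only guide available. Compound 3 is thus estimated at 120 nM, within a range from 35 nM to 400 nM, which corresponds to an expected step of a 9.2-fold higher number from compound 1 to compound 3 (0.97 log units; beyond the scatter).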

Compound 3, half-maximal inhibitory concentration: 97 nM
Compound 3: the middle estimate sits 1.2-fold (0.09 log units) above what was measured; the measured number falls inside the stated range.
By their numbers in this assay, from the lowest: compound 1; then compound 3; then compound 2.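

In this assay the carbamoylmethyl on this oxygen also gives a weaker inhibitor than the free hydroxymethyl (a 7.5-fold higher number from compound 1 to compound 3 (0.87 log units; beyond the scatter)), so two different groups placed here now point the same way. The outer part of the attached group counts as well: amino in place of methoxy on a carbonyl carbon recovers part of the loss (a 2.7-fold lower number from compound 2 to compound 3 (0.43 log units; beyond the scatter)), which shows that the size of the penalty depends on what the group carries and not merely on the hydrogen being replaced. Neither compound 2 nor compound 3 comes close to compound 1 here, and no supporting measurement is available to say why these steps take the sizes they do.

Still open, as far as these compounds go, is whether a plain methyl on this oxygen would stay closer to compound 1, or whether a carboxylic acid in place of the ester or the primary amide would widen or narrow the loss. A longer chain carrying the same amide, or an amine in place of the amide, would show whether any group attached to this oxygen can match the free hydroxymethyl.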